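The source may hold more compounds than are shown below. What is called first, only, known or untested is meant among the compounds shown, and "the series" means these compounds.

Compound 1: `CCCCCCCCCCCC(=O)OCCc1ccc(O)cc1` — in a toxicity assay on MRC5 cells (Homo sapiens) for inhibition, read by MTT assay, with a stated time of 72 h (on this read-out higher numbers stand for weaker inhibition and lower numbers for stronger inhibition), compound 1 gives 67200 nM.
Compound 2: `CCCCCCCCCCCCCCCC(=O)OCCc1ccc(O)c(O)c1` — in this assay compound 2 gives only a limit, > 50000 nM.

Compound 2 therefore stands at a limit of the assay rather than at a number (the limit of > 50000 nM in this assay, at which 1 of the 2 values shown sits). Compound 3, `CCCCCCCCCCCCC(=O)OCCc1ccc(O)c(O)c1`, differs from compound 2 in one place: hydrogen in place of propyl on a saturated chain carbon, ten or more bonds along the chain from a carbonyl carbon. Among the measured compounds shown here, no two measured compounds differ in a single place, so there is no measured step to lean on; the change in this assay is expected to be none beyond the scatter. Compound 3 is expected to sit near 70000 nM, within 30000 nM to 160000 nM, an expected step that the limit leaves unreadable from compound 2 to compound 3 from its neighbour.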

Compound 3, half-maximal inhibitory concentration: 13200 nM
Beside the measured number, compound 3's estimate is 5.3-fold (0.72 log units) above it, and the stated range ends above it.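

In this assay there is an at least 3.7-fold lower number from compound 2 to compound 3 (0.57 log units; beyond the scatter), so hydrogen in place of propyl on a saturated chain carbon, this far along the chain from a carbonyl carbon, is not a silent change: the shorter chain gives stronger inhibition of the cells. As far as these compounds go, the true size of the step stays unknown because compound 2 gives only a limit: the limit of > 50000 nM in this assay, at which 1 of the 3 values shown sits.

This single pair cannot show how the read-out follows chain length from one length to the next. From the compounds shown here alone, whether a much shorter chain, or a carboxylic acid at the chain end, would move the number further also stays open.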